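The compounds below may be only part of what the source reports. "The series", "measured", "known", "first", "only" and "open" are said of these compounds alone.

Compound 1 `Cc1ncnc2[nH]cc(Sc3cccs3)c12` sits at the detection limit of a functional assay on A549 cells (Homo sapiens), read by MTT assay, with a stated time of 3 days; a higher number here means a weaker inhibitor, a lower number a stronger inhibitor: its value of > 50000 nM is a limit, not a number, as the evidence the limit of > 50000 nM in this assay, at which 1 of the 2 values shown sits, shows. Compound 2 `c1csc(Sc2c[nH]c3ncnc(-c4cccs4)c23)c1` gives 16200 nM in the same assay, a change of an at least 3.0-fold lower number from compound 1 to compound 2 (0.48 log units; beyond the scatter). Compound 3 `Nc1ncnc2[nH]cc(Sc3cccs3)c12` differs from compound 1 by amino in place of methyl on an aromatic carbon. Going by the values given here, no measured step exchanges methyl for amino, so the expectation for this assay is a step of a number no higher from compound 1 to compound 3 (the limit leaves the size open), with wide uncertainty. Compound 3 is estimated at 50000 nM, between 15000 nM and 150000 nM.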

Compound 3, half-maximal inhibitory concentration: 22800 nM
Compound 3: the middle estimate sits 2.2-fold (0.34 log units) above what was measured; the range from low to high includes it.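

Swapping methyl for amino at this position also brings a measurable value in this assay, with an at least 2.1-fold lower number from compound 1 to compound 3 (0.34 log units; beyond the scatter). Thiophen-2-yl is therefore not the only group here that gives a number, and the two cannot be told apart, with a 1.4-fold higher number from compound 2 to compound 3 (0.15 log units; within the scatter). Going by these compounds, the value of compound 1 is a limit, so the full size of the first step stays open: the limit of > 50000 nM in this assay, at which 1 of the 3 values shown sits.

On these data alone, whether a methoxy group, a carboxylic acid or a longer chain here would lower the number further remains open. Why methyl differs from the other two groups also remains unknown.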